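Methoxy to chloro on the phenoxy ring of compound 2

This account rests on a few compounds, and the source may have more. Where it says the series, first, only, none or still open, it means among the compounds named here.

In an assay on isolated protein for positive allosteric modulation of muscarinic acetylcholine receptor M5 (Homo sapiens) (a higher number here means a larger maximal response, a lower number a smaller maximal response), compound 2 `COc1ccc(OCCN2C(=O)C(=O)c3cc(OC(F)(F)F)ccc32)cc1` gives 89%, and compound 1 `O=C1C(=O)N(CCOc2ccccc2)c2ccc(OC(F)(F)F)cc21` gives 91%; the two numbers lie within the scatter of each other, so no difference between them can be claimed. Compound 3 `O=C1C(=O)N(CCOc2ccc(Cl)cc2)c2ccc(OC(F)(F)F)cc21` differs from compound 2 by chloro in place of methoxy on an aromatic carbon. Going by the values given here, no measured step covers this exact swap. Among the compounds with values here, the only step recorded, a number 2 percentage points lower from compound 1 to compound 2 (within the scatter), shows that a change at this aromatic carbon left the maximal response unchanged. A step of about no change at the digits printed from compound 2 to compound 3 (within the scatter) is therefore expected, none beyond the scatter. Compound 3 is estimated at 89%, within 76% to 102%.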

Compound 3, largest response reached (Emax), in percent of the reference or control that the assay uses: 92%
Beside the measured number, compound 3's estimate is 3 percentage points below it; low and high end bracket the measured number.
By their numbers in this assay, from the lowest: compounds 2, 1 and 3 (each within the scatter of the next).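

In this assay, chloro at this position, para to a large group, gives no difference from methoxy: a number 3 percentage points higher from compound 2 to compound 3 (within the scatter). Against hydrogen the picture is the same, a number 1 percentage points higher from compound 1 to compound 3 (within the scatter), so all three groups on this aromatic carbon sit within the scatter, whether the group carries a hydrogen-bond acceptor, as methoxy does, or none, as chloro does. Nothing available explains this tolerance.

Open, going by these compounds, is whether a charged group such as an amine or a carboxylic acid at this position would hold the maximal response. Also open, on these data alone, is whether a longer chain in place of methoxy would do so.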